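The compounds below may be only part of what the source reports. "The series", "measured", "known", "first", "only" and "open" are said of these compounds alone.

Measured compounds:
compound 1, `Cc1ccc(-c2ccc(=O)n(-c3ccc(S(=O)(=O)NC(=O)NC4CCCCC4)cc3)n2)cc1`, 110%
compound 2, `CCCNC(=O)NS(=O)(=O)c1ccc(-n2nc(-c3ccc(Cl)cc3)ccc2=O)cc1`, 122%

In a functional assay on the whole organism (blood, strain Wistar albino) for inhibition, with Rattus norvegicus as the target, read by colorimetric assay, with stated times of 15 min and 90 min, at a dose of 20 mg/kg by the oral route (on this read-out lower numbers stand for less inhibition and higher numbers for more inhibition at the one dose given (going by the name of the read-out)), compound 2 stands highest of the two numbers, with compound 1 the nearer one at a lower value, a gap beyond the usual scatter. Compound 3, `O=C(NC1CCCCC1)NS(=O)(=O)c1ccc(-n2nc(-c3ccc(Cl)cc3)ccc2=O)cc1`, is not yet measured; it differs from compound 2 by cyclohexyl in place of propyl on an amide-type nitrogen. Within the data shown here, no step between measured compounds speaks to this change, so a small step is expected, if any: the estimate for compound 3 in this assay is 115%, within 100% to 130%, an expected step of a number 7 percentage points lower from compound 2 to compound 3 (within the scatter) that may well lie within the scatter.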

Compound 3, a percentage reported as inhibition, in the whole organism at one dose (the size of the read-out at that dose, not a potency): 114%
Compound 3: middle estimate off by 1 percentage points, on the high side; the range from low to high includes it.
By their numbers in this assay, from the lowest: compounds 1, 3 and 2 (each within the scatter of the next, the first and the last beyond it).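

In this assay, cyclohexyl in place of propyl on the amide-type nitrogen gives a number 8 percentage points lower from compound 2 to compound 3 (within the scatter), so the read-out does not separate these two groups at this position. With cyclohexyl held in place, chloro in place of methyl on an aromatic carbon gives a number 4 percentage points higher from compound 1 to compound 3 (within the scatter), so neither single change gives a step beyond the scatter. Nothing available explains either step. From the compounds shown here alone, whether a phenyl ring or a longer chain such as octyl on that nitrogen would read differently remains open, as does the effect of methoxy on that aromatic carbon.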